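Aryl amine variation on the shared core

This account rests on a few compounds, and the source may have more. Where it says the series, first, only, none or still open, it means among the compounds named here.

Compound 1 `COc1ccc(Nc2nc(SCc3cn(CC(=O)NC(=O)Nc4ccccn4)nn3)nc(-c3ccc(C(C)C)cc3)c2C#N)cc1` and compound 2 `Cc1ccccc1Nc1nc(SCc2cn(CC(=O)NC(=O)Nc3ccccn3)nn2)nc(-c2ccc(C(C)C)cc2)c1C#N` share one core and differ only in the aryl group on the ring nitrogen. In a functional assay on ECa-109 cells (Homo sapiens) for inhibition, read by MTT assay, with a stated time of 72 h (a higher number here means a weaker inhibitor, a lower number a stronger inhibitor), compound 1 gives 5420 nM and compound 2 gives 7230 nM. Compound 2 stands at the higher of the two numbers, but the step of a 1.3-fold higher number from compound 1 to compound 2 (0.13 log units; within the scatter) lies within the scatter, so the two aryl groups read alike on these data.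

Compound 3 `CC(C)c1ccc(Nc2nc(SCc3cn(CC(=O)NC(=O)Nc4ccccn4)nn3)nc(-c3ccc(C(C)C)cc3)c2C#N)cc1` is not yet measured. It differs from compound 2 by 4-isopropylphenyl in place of 2-methylphenyl on a nitrogen on an aromatic ring. Going by the values given here, the only measured step at this position, a 1.3-fold higher number from compound 1 to compound 2 (0.13 log units; within the scatter), gave nothing beyond the scatter, and no measured compound carries the entering group on this nitrogen. On that basis the expected step in this assay is a 1.1-fold lower number from compound 2 to compound 3 (0.05 log units; within the scatter), none beyond the scatter in either direction. Compound 3 is expected to give 6500 nM in this assay, with a range of 2500 nM to 17000 nM.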

Compound 3, half-maximal inhibitory concentration: 2490 nM
Compound 3: middle estimate off by 2.6-fold (0.42 log units), on the high side, and the stated range ends above it.
By their numbers in this assay, from the lowest: compound 3; then compounds 1 and 2 (each within the scatter of the next).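

In this assay the aryl group on this nitrogen now matters, with a 2.9-fold lower number from compound 2 to compound 3 (0.46 log units; beyond the scatter) and a 2.2-fold lower number from compound 1 to compound 3 (0.34 log units; beyond the scatter), whereas the earlier pair read alike. Compound 3 therefore separates from both compounds with modest steps, and 4-isopropylphenyl is the only one of the three aryl groups that stands apart at this position. No measurement at hand bears on the origin of this shift.

The step from compound 2 changes both the substituent and where it sits on the phenyl ring, so these two contributions cannot be separated on the present data. Also open, as far as these compounds go, is whether the trend continues with a tert-butyl group or a longer alkyl chain on the phenyl ring, or whether an amine or a carboxylic acid there would reverse it.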